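A Methyl Added to a Weak Inhibitor

The source may report more compounds than this note shows. Statements on the series, on what has been measured and on what is new or still open speak of the compounds shown alone.

Compound 1, `Cc1[nH]c2ccccc2c1C1CC(c2ccncc2)=NO1`: 95500 nM
Compound 2, `Clc1ccc(Cn2cc(C3CC(c4ccncc4)=NO3)c3ccccc32)cc1`: > 100000 nM

Of the compounds shown here, two have been measured in a functional assay on BXPC-3 cells (Homo sapiens) for inhibition, read by MTT assay, with a stated time of 48 h; a lower number here means a stronger inhibitor, a higher number a weaker inhibitor. Compound 1 gives 95500 nM in this assay, a very weak result. Compound 2 gives only a limit in this assay, > 100000 nM, which is not a measured number but the boundary of what the assay can report. That is where compound 2 stands: at the limit of > 100000 nM in this assay, at which 1 of the 2 values shown sits. The two values shown are both at the weak end of the scale.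

Compound 3, `Cc1c(C2CC(c3ccncc3)=NO2)c2ccccc2n1Cc1ccc(Cl)cc1`, has not yet been measured in this assay. It differs from compound 2 by methyl in place of hydrogen on an aromatic carbon of a five-membered aromatic ring with one nitrogen, part of a fused system of two rings, next to the ring nitrogen and next to the ring atom that bears a 4-chlorobenzyl group.

Among the measured compounds shown here, no measured step covers a change of this kind here. A single methyl added to a compound that already sits at the limit is expected to give no step beyond the scatter, so the step from compound 2 to compound 3 is estimated as a number no higher from compound 2 to compound 3 (the limit leaves the size open). Compound 3 is therefore expected to give about 100000 nM in this assay, somewhere between 40000 nM and 300000 nM, with a fair chance that only a limit is reported again.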

Compound 3, half-maximal inhibitory concentration: 13500 nM
Compound 3: the middle estimate sits 7.4-fold (0.87 log units) above what was measured, outside the stated range (below it).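

In this assay, the methyl on the aromatic carbon next to the ring nitrogen turns out not to be a silent change: it gives an at least 7.4-fold lower number from compound 2 to compound 3 (0.86 log units; beyond the scatter), so this one carbon matters when a 4-chlorobenzyl group sits on the ring nitrogen. The other single change, 4-chlorobenzyl in place of hydrogen on the aromatic nitrogen with the methyl already present, gives a 7.1-fold lower number from compound 1 to compound 3 (0.85 log units; beyond the scatter), so compound 3, at 13500 nM, stands ahead of both of its neighbours while remaining a weak inhibitor in absolute terms. The true size of the methyl step remains unknown, since the figure for compound 2 is a limit of the assay and not a number, which makes the step a minimum: the limit of > 100000 nM in this assay, at which 1 of the 3 values shown sits.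

The compounds shown leave open whether something other than methyl on this carbon, such as an ethyl group, a chlorine atom or a methoxy group, would give a similar step. They also leave open whether the methyl step would hold with a different group on the ring nitrogen, such as a plain benzyl group or a longer chain.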